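A few compounds are considered here, and "the series" means these few. Any claim that something is new, unique, unknown or untested is made for them only; others in the source may bear on it.

For the measured compounds named here, only two compounds have been measured so far in an ADME assay (liver) for metabolic stability, with Liver microsome (Homo sapiens) as the target, using microsomes; a lower number here means slower removal, a higher number faster removal of the compound. Compound 1 `Fc1cc2cc(-c3nnc(NCc4ccccc4)o3)ccc2cn1` gives 49 mL.min-1.g-1, and compound 2 `c1ccc(CNc2nnc(-c3c[nH]c4ncccc34)o2)cc1` gives 31 mL.min-1.g-1. These two numbers lie within the usual scatter of each other, so neither compound stands apart from the other. The next structure, compound 3 `Fc1ccccc1CNc1nnc(-c2c[nH]c3ncccc23)o1`, differs from compound 2 in one place: fluoro in place of hydrogen on an aromatic carbon. This puts fluoro in place of hydrogen on an aromatic carbon, ortho to a large group, turning phenyl to 2-fluorophenyl. Going by the values given here, no measured pair differs in just one place, so the data offer no direct guide to the size of this step. The expected step of a 1.0-fold lower number from compound 2 to compound 3 (0.01 log units; within the scatter) lies within the scatter, with no direction favoured. The best anchor is therefore compound 2 at 31 mL.min-1.g-1. For compound 3 the estimated value is 30 mL.min-1.g-1, with an expected range of 16 mL.min-1.g-1 to 58 mL.min-1.g-1.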

Compound 3, intrinsic clearance in microsomes: 32 mL.min-1.g-1
Compound 3: the middle estimate sits 1.1-fold (0.03 log units) below what was measured; measured number inside the range.
By their numbers in this assay, from the lowest: compounds 2, 3 and 1 (each within the scatter of the next).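

Turning phenyl to 2-fluorophenyl in this assay gives a 1.0-fold higher number from compound 2 to compound 3 (0.01 log units; within the scatter) and so the two numbers cannot be told apart. For the compounds shown here, this is the first pair here that differs in just one place, and it shows that, on this aromatic carbon ortho to a large group, a single fluoro in place of hydrogen leaves no measurable mark on the read-out. Nothing at hand points to a cause for this result.

Fluoro is the only replacement for hydrogen shown at this position, so it remains open whether a chloro, methyl or methoxy group there would also leave the number within the scatter. A single pair also cannot say whether fluoro would behave the same way on the benzyl ring of a compound with a different core, such as compound 1.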